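The compounds below may be only part of what the source reports. "The series", "measured", "known", "first", "only" and "open" are said of these compounds alone.

Working notes on the series. In a functional assay on HL-60 cells (Homo sapiens) for cytotoxicity, read by luminescence and CellTiter-Glo, with a stated time of 3 days (a lower number here means a stronger inhibitor, a higher number a weaker inhibitor), compound 1 `COc1ccc(O)c(C(=O)Nc2ccc(C#N)cc2)c1` reports only a limit, > 10000 nM, not a number. Compound 2 `O=C(Nc1cc(C(F)(F)F)cc(C(F)(F)F)c1)c1cc(F)ccc1O`, which differs in several places, gives 320 nM in this assay. The step to compound 3 `Cc1ccc(O)c(C(=O)Nc2ccc(C#N)cc2)c1` is methyl in place of methoxy on an aromatic carbon. Compound 1 stands at the limit, as noted in the limit of > 10000 nM in this assay, at which 1 of the 2 values shown sits. Because compound 1 sits at > 10000 nM, no movement beyond the scatter is expected in this assay, and the step that the limit leaves unreadable from compound 1 to compound 3 is taken as an estimate only. Compound 3 is expected near 12000 nM, within 3000 nM to 40000 nM, most likely again as a limit.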

Compound 3, half-maximal inhibitory concentration: 3920 nM
Compound 3: middle estimate off by 3.1-fold (0.49 log units), on the high side; the measured number falls inside the stated range.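

In this assay compound 1 gives > 10000 nM as a limit, not a number. Methyl in place of methoxy, on this aromatic carbon para to a hydroxy group, gives an at least 2.5-fold lower number from compound 1 to compound 3 (0.40 log units; beyond the scatter) and so shows that this position responds to the change. From the compounds shown here alone, the true size of the step remains unknown, and only its lower bound can be read: the limit of > 10000 nM in this assay, at which 1 of the 3 values shown sits.

Going by these compounds, whether an amine or a carboxylic acid at this position would lower the number further remains open. So does whether the step carries over to the core of compound 2.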